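The source may hold more compounds than are shown below. What is called first, only, known or untested is meant among the compounds shown, and "the series" means these compounds.

In a functional assay on HepG2 cells (Homo sapiens) for antiproliferative activity, read by MTT assay, with a stated time of 48 h (on this read-out lower numbers stand for stronger inhibition and higher numbers for weaker inhibition), compound 1 `CN1CCN(CC(=O)Nc2ccc3ncnc(Nc4ccc(Br)cc4)c3c2)CC1` gives > 100000 nM, which is a limit of the assay and not a number. Compound 2 `O=C(CN1CCCC1)Nc1ccc2ncnc(Nc3ccc(Cl)c(C(F)(F)F)c3)c2c1` also gives only a limit, > 100000 nM. Compound 3 `O=C(CN1CCCCC1)Nc1ccc2ncnc(Nc3ccc(Cl)c(C(F)(F)F)c3)c2c1` stands at a limit as well, > 100000 nM, so its position is known only from that side. The evidence so far comes down to the limit of > 100000 nM in this assay, at which 3 of the 3 values shown sit.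

Compound 4 `CN1CCN(CC(=O)Nc2ccc3ncnc(Nc4ccc(Cl)c(C(F)(F)F)c4)c3c2)CC1` departs from compound 3 in one group: 4-methylpiperazin-1-yl in place of piperidin-1-yl on a saturated chain carbon bound to a carbonyl carbon. In words, this puts 4-methylpiperazin-1-yl in place of piperidin-1-yl on a saturated chain carbon bound to a carbonyl carbon.

Among the measured compounds shown here, the only measured step that bears on this change swaps the group at the same place, and it is a step that the two limits leave unreadable from compound 2 to compound 3. It therefore gives no size to carry forward. The entering group is not new to the set, since compound 1 also carries 4-methylpiperazin-1-yl and its reading is the limit > 100000 nM.

With no readable step pointing either way, no shift beyond the scatter is expected in this assay, and a further limit is the likeliest outcome. The expected change is a number no higher from compound 3 to compound 4 (the limit leaves the size open). For compound 4 the estimated value is 100000 nM, with an expected range of 30000 nM to 200000 nM.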

Compound 4, half-maximal inhibitory concentration: 25300 nM
The estimate for compound 4 lay 4.0-fold (0.60 log units) above the measured number, and the stated range ends above it.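

In this assay, the change on a saturated chain carbon bound to a carbonyl carbon now has a readable size: 4-methylpiperazin-1-yl in place of piperidin-1-yl gives an at least 3.9-fold lower number from compound 3 to compound 4 (0.59 log units; beyond the scatter), and in place of pyrrolidin-1-yl it gives an at least 3.9-fold lower number from compound 2 to compound 4 (0.59 log units; beyond the scatter). The entering group does not give a number on its own, as compound 1 carries it and stays at a limit, so the other place counts too: 4-chloro-3-(trifluoromethyl)phenyl in place of 4-bromophenyl on a nitrogen on an aromatic ring gives an at least 3.9-fold lower number from compound 1 to compound 4 (0.59 log units; beyond the scatter). Among these compounds, a number appears only where 4-methylpiperazin-1-yl and 4-chloro-3-(trifluoromethyl)phenyl occur together, and each of these sizes is only a lower bound, with the other end of each step a limit: the limit of > 100000 nM in this assay, at which 3 of the 4 values shown sit.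

The compounds shown leave open whether the second ring nitrogen or its methyl group goes with this step, which piperazin-1-yl without the methyl or morpholin-4-yl at the same place could separate. They also leave open how a longer chain at that place, or a 4-fluorophenyl on the nitrogen on an aromatic ring, would read.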